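Methylsulfanyl in Place of Acetyl: Compound 3 to Compound 4

The source may hold more compounds than are shown below. What is called first, only, known or untested is meant among the compounds shown, and "the series" means these compounds.

In an assay on HEK-293T cells for inhibition of diacylglycerol lipase-alpha (Homo sapiens), read by colorimetric assay (a higher number here means a weaker inhibitor, a lower number a stronger inhibitor), compound 3 `CC(=O)c1coc(C(=O)CCCCCCc2ccccc2)n1` gives 123 nM, the lowest of the two numbers recorded. Compound 2 `O=C(CCCCCc1ccccc1)c1nc2cccnc2o1` gives 1700 nM in this assay, a gap from compound 3 that lies beyond the scatter. For compound 1 `O=C(CCCCCc1ccccc1)c1nc2ncccc2s1` this assay reports only a limit, > 10000 nM, as noted in the limit of > 10000 nM in this assay, at which 1 of the 3 values shown sits. Compound 4 `CSc1coc(C(=O)CCCCCCc2ccccc2)n1` differs from compound 3 in a single place: methylsulfanyl in place of acetyl on an aromatic carbon. Going by the values given here, no measured pair isolates this change, so its effect on this assay is not yet known from the data. The step of a 2.0-fold higher number from compound 3 to compound 4 (0.31 log units; beyond the scatter) is expected to be modest, most likely a small loss or none beyond the scatter. Compound 4 is therefore estimated at 250 nM, with a range from 80 nM to 800 nM.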

Compound 4, half-maximal inhibitory concentration: > 10000 nM
Compound 4 ended at the assay's limit; the forecaster's own chance of this, stated with the estimate: 5%; middle value at least 40-fold (1.60 log units) away from the limit.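

Putting methylsulfanyl in place of acetyl, next to the ring nitrogen, is far from a neutral exchange: in this assay it gives an at least 81-fold higher number from compound 3 to compound 4 (1.91 log units; beyond the scatter). The activity of compound 3 therefore depends heavily on the group at this position, and the rest of the structure does not carry it alone. The value of compound 4 is a limit and not a number: the limit of > 10000 nM in this assay, at which 2 of the 4 values shown sit.

The compounds shown leave open whether the carbonyl of the acetyl is what counts. They do not say how a methyl ester, a primary amide or a nitrile would fare at this position.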